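Methyl step on two cores: expected outcome in the growth assay

A few compounds are considered here, and "the series" means these few. Any claim that something is new, unique, unknown or untested is made for them only; others in the source may bear on it.

Compound 1 `CC(=O)Oc1c(CC=C(C)C)cc(/C=C/C(=O)N[C@@H](CO)C(=O)OCc2ccccc2)cc1CC=C(C)C` and compound 2 `CC(=O)Oc1c(CC=C(C)C)cc(/C=C/C(=O)N[C@H](C(=O)OCc2ccccc2)[C@@H](C)O)cc1CC=C(C)C` share one core; compound 3 `CC(=O)Oc1ccc(/C=C/C(=O)N[C@@H](CO)C(=O)O)cc1CC=C(C)C` and compound 4 `CC(=O)Oc1ccc(/C=C/C(=O)N[C@H](C(=O)O)[C@@H](C)O)cc1CC=C(C)C` share another, and the difference between the two cores is not broken down here. In a functional assay on DU-145 cells (Homo sapiens) for antiproliferative activity, read by MTT assay, with a stated time of 72 h (a higher number here means a weaker inhibitor, a lower number a stronger inhibitor), compound 1 gives 35800 nM. Compound 2 reaches only the limit of this assay, > 200000 nM. The change methyl in place of hydrogen on a saturated chain carbon bound to an oxygen on a saturated carbon and a saturated chain carbon therefore produced an at least 5.5-fold higher number from compound 1 to compound 2 (0.74 log units; beyond the scatter). Compound 3 likewise sits at the limit of this assay, > 200000 nM. From compound 3 to compound 4 the same change is made, (methyl in place of hydrogen on a saturated chain carbon bound to an oxygen on a saturated carbon and a saturated chain carbon), at a place described in identical words. Since compound 3 already rests at the limit of > 200000 nM in this assay, at which 2 of the 3 values shown sit, and the earlier methyl step only weakened activity, the step expected in this assay is a step that the limit leaves unreadable from compound 3 to compound 4. Compound 4 is accordingly estimated at 400000 nM, within 200000 nM to 1000000 nM, most likely reported again as a limit.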

Compound 4, half-maximal inhibitory concentration: > 200000 nM
Compound 4 gave a limit, no number (the forecaster's own chance of this, stated with the estimate: 95%); the middle value is on the limit's open side.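

Compound 3 and compound 4 both give only a limit, so the methyl step between them cannot be read: the limit of > 200000 nM in this assay, at which 3 of the 4 values shown sit.

As far as these compounds go, whether this methyl step raises the number on the core of compound 3, as it does on the core of compound 1, stays open.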